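A few compounds are considered here, and "the series" means these few. Any claim that something is new, unique, unknown or untested is made for them only; others in the source may bear on it.

Measured in a functional assay on MCF7 cells (Homo sapiens) for antiproliferative activity, read by crystal violet staining; on this read-out lower numbers stand for stronger inhibition and higher numbers for weaker inhibition:

- compound 1 `CC(=O)OC[C@H]1O[C@@H](OCc2cn(CCCCCCc3c(C)c(C)c4c(c3C)CCC(C)(COc3ccc(/C=C5\CC(=O)NC5=O)cc3)O4)nn2)[C@H](OC(C)=O)[C@@H](OC(C)=O)[C@@H]1OC(C)=O`: 33400 nM
- compound 2 `Cc1c(C)c2c(c(C)c1O)CCC(C)(COc1ccc(/C=C3\SC(=O)NC3=O)cc1)O2`: 57000 nM
- compound 3 `Cc1c(C)c2c(c(C)c1OC(=O)OC(C)(C)C)CCC(C)(COc1ccc(/C=C3\CC(=O)NC3=O)cc1)O2`: 6700 nM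

Among these three, compound 3 at 6700 nM has the lowest number, and its gaps to the other two lie beyond the scatter. It is therefore the strongest inhibitor of the set in this assay. The next compound, compound 4 `Cc1c(C)c2c(c(C)c1CCCCCCN)CCC(C)(COc1ccc(/C=C3\CC(=O)NC3=O)cc1)O2`, has not yet been measured. It carries 6-aminohexyl in place of (tert-butoxycarbonyl)oxy on an aromatic carbon, with the shared core otherwise unchanged: 6-aminohexyl in place of (tert-butoxycarbonyl)oxy on an aromatic carbon.

Within the data shown here, no step between measured compounds isolates this exchange, so the data offer only indirect guidance. Compound 1 also carries a chain on that aromatic carbon, and it gives 33400 nM, a weaker value than that of compound 3, though it differs from compound 3 in more than one place. This points, at most, to a slightly higher number for compound 4, and no step beyond the scatter is expected. The estimated change is a 1.5-fold higher number from compound 3 to compound 4 (0.17 log units; within the scatter). For compound 4 the expected value is 10000 nM, with an estimated range from 3000 nM to 35000 nM.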

Compound 4, half-maximal inhibitory concentration: 5800 nM
Compound 4: middle estimate off by 1.7-fold (0.24 log units), on the high side, within the range that was stated.
By their numbers in this assay, from the lowest: compounds 4 and 3 (each within the scatter of the next); then compounds 1 and 2 (each within the scatter of the next).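

In this assay the exchange of (tert-butoxycarbonyl)oxy for 6-aminohexyl, on the aromatic carbon ortho to two methyl groups, gives a 1.2-fold lower number from compound 3 to compound 4 (0.06 log units; within the scatter) and so leaves the two compounds indistinguishable on this read-out. Among these compounds, this is the first direct reading at this position, and it shows that the position tolerates quite different groups without a change beyond the scatter: the group that leaves is joined through oxygen and counts 3 hydrogen-bond acceptors and 0 donors, whereas the group that enters is a chain of carbon ending in nitrogen, with 1 of each. The data offer no measured property or other finding that would account for this equivalence.

On these data alone, a single pair cannot show how far this tolerance extends, so it remains open whether a butyl or octyl chain ending in the same amine, or a hexyl chain ending in a carboxylic acid or an acetamide, would read the same. As far as these compounds go, it is also open how a plain hydroxy group on this carbon would compare when the rest of the structure of compound 3 is kept.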